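Second chloro on the anilide ring of compound 3

The source may report more compounds than this note shows. Statements on the series, on what has been measured and on what is new or still open speak of the compounds shown alone.

Going by the values given here, compound 3 `O=C(CSc1nc(Nc2ccccc2)c2ccccc2n1)Nc1ccc(Cl)cc1` gives 17200 nM in a functional assay on MDA-MB-231 cells (Homo sapiens) for inhibition, read by MTT assay, with a stated time of 72 h (on this read-out higher numbers stand for weaker inhibition and lower numbers for stronger inhibition), one of only two numbers in hand. Compound 2 `C=CC(=O)Nc1cccc(NC(=O)CSc2nc(Nc3ccccc3)c3ccccc3n2)c1` gives 10200 nM, and the difference a 1.7-fold higher number from compound 2 to compound 3 (0.23 log units; within the scatter) falls within the scatter, so the two are indistinguishable. Compound 1 `O=C(CSc1nc(Nc2ccccc2)c2ccccc2n1)Nc1cccc(F)c1` reaches only the assay limit at > 50000 nM. The steps of an at least 4.9-fold lower number from compound 1 to compound 2 (0.69 log units; beyond the scatter) and an at least 2.9-fold lower number from compound 1 to compound 3 (0.46 log units; beyond the scatter) show that the anilide part can move the number by at least a modest amount. Compound 4 `O=C(CSc1nc(Nc2ccccc2)c2ccccc2n1)Nc1ccc(Cl)cc1Cl` differs from compound 3 by chloro in place of hydrogen on an aromatic carbon. Among the compounds with values here, no measured step adds a second halogen to an anilide ring that already carries one, so the step of a 1.3-fold lower number from compound 3 to compound 4 (0.12 log units; within the scatter) is expected to stay within the scatter, with no clear direction. The number for compound 4 in this assay is therefore estimated at 13000 nM, between 4000 nM and 45000 nM.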

Compound 4, half-maximal inhibitory concentration: 19400 nM
Estimate against measurement, compound 4: 1.5-fold (0.17 log units) below, and the stated range covers the measured number.
By their numbers in this assay, from the lowest: compounds 2, 3 and 4 (each within the scatter of the next). At a limit, above all of these: compound 1.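

In this assay the change from 4-chlorophenyl to 2,4-dichlorophenyl gives a 1.1-fold higher number from compound 3 to compound 4 (0.05 log units; within the scatter) and so chloro ortho to a large group brings no readable shift. With a 1.9-fold higher number from compound 2 to compound 4 (0.28 log units; within the scatter) the 2,4-dichlorophenyl anilide also cannot be told apart from the (vinylcarbonyl)amino anilide, while an at least 2.5-fold lower number from compound 1 to compound 4 (0.41 log units; beyond the scatter) sets it apart from the 3-fluorophenyl anilide. Compound 1 stands at a limit, not a number: the limit of > 50000 nM in this assay, at which 1 of the 4 values shown sits.

Open, from the compounds shown here alone, is whether an amine or a carboxylic acid in place of chloro here would move the number. Also open, going by these compounds, is whether any anilide change reaches beyond the scatter among compounds 2, 3 and 4.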